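Compound 4: 4-Chloro-3-(trifluoromethyl)phenyl Replaces 4-Methoxyphenyl

The compounds below may be only part of what the source reports. "The series", "measured", "known", "first", "only" and "open" are said of these compounds alone.

Compound 3 `COc1ccc(NC(=O)Nc2cccc(-c3nc(-c4ccc(NC(=O)c5cccnc5)cc4Cl)no3)c2)cc1` carries a 4-methoxyphenyl on an amide-type nitrogen of the shared core. In a functional assay on MDA-MB-231 cells (Homo sapiens) for antiproliferative activity, read by MTT assay, with a stated time of 72 h (on this read-out lower numbers stand for stronger inhibition and higher numbers for weaker inhibition), compound 3 gives 3000 nM, which places it second highest among the three measured compounds. Compound 1 `O=C(Nc1cccc(-c2nc(-c3ccc(NC(=O)c4cccnc4)cc3Cl)no2)c1)Nc1cccc(C(F)(F)F)c1`, with a 3-(trifluoromethyl)phenyl on that nitrogen, gives 1900 nM, and the step of a 1.6-fold higher number from compound 1 to compound 3 (0.20 log units; within the scatter) lies within the scatter. Compound 2 `COc1cccc(NC(=O)Nc2cccc(-c3nc(-c4ccc(NC(=O)c5cccnc5)cc4Cl)no3)c2)c1`, with a 3-methoxyphenyl, gives 6700 nM; the step of a 2.2-fold lower number from compound 2 to compound 3 (0.35 log units; beyond the scatter) is the only one beyond the scatter that involves compound 3. Compound 4 `O=C(Nc1cccc(-c2nc(-c3ccc(NC(=O)c4cccnc4)cc3Cl)no2)c1)Nc1ccc(Cl)c(C(F)(F)F)c1` has not yet been measured in this assay. The change from compound 3 to compound 4 is 4-chloro-3-(trifluoromethyl)phenyl in place of 4-methoxyphenyl on an amide-type nitrogen. For the measured compounds named here, the trifluoromethyl group that enters is already present in compound 1, and no measured step shows the effect of the chlorine that also enters. Because the step of a 1.6-fold higher number from compound 1 to compound 3 (0.20 log units; within the scatter) was small, compound 4 is expected to show only a modest step of a 2.5-fold lower number from compound 3 to compound 4 (0.40 log units; beyond the scatter). The estimate for compound 4 is 1200 nM, with an expected range from 400 nM to 4000 nM.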

Compound 4, half-maximal inhibitory concentration: 1900 nM
Compound 4: middle estimate off by 1.6-fold (0.20 log units), on the low side; the range from low to high includes it.
By their numbers in this assay, from the lowest: compounds 1, 4 and 3 (each within the scatter of the next); then compound 2.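

In this assay, for the compounds shown here, chloro in place of hydrogen on an aromatic carbon gives a step that no earlier pair could show (no change at the digits printed from compound 1 to compound 4 (within the scatter)), so adding this chlorine to the 3-(trifluoromethyl)phenyl group leaves the read-out within the scatter. The 4-chloro-3-(trifluoromethyl)phenyl group also stays within the scatter of 4-methoxyphenyl (a 1.6-fold lower number from compound 3 to compound 4 (0.20 log units; within the scatter)) but stands apart from 3-methoxyphenyl (a 3.5-fold lower number from compound 2 to compound 4 (0.55 log units; beyond the scatter)), which leaves compound 2 as the only one of the four separated from all the others by steps beyond the scatter. Nothing given here accounts for these steps.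

The compounds shown leave open how a phenyl group bearing chloro alone would read on this amide-type nitrogen. They also leave open whether an amine or a carboxylic acid on that phenyl group would give a step beyond the scatter.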